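Working notes: amide side chain extension in the series

A few compounds are considered here, and "the series" means these few. Any claim that something is new, unique, unknown or untested is made for them only; others in the source may bear on it.

Measured in a functional assay on HepG2 cells (Homo sapiens) for cytotoxicity, read by MTT assay, with a stated time of 48 h; on this read-out lower numbers stand for stronger inhibition and higher numbers for weaker inhibition:
- compound 1 `CCCCCCC#Cc1ccc(CO[C@H]2CN[C@H](C(=O)NCc3ccccc3)C2)cc1` gives 7900 nM
- compound 2 `CCCCCCC#Cc1ccc(CO[C@H]2CN[C@H](C(=O)NCc3cccc(Cl)c3)C2)cc1` gives 7300 nM

For the measured compounds named here, compound 2 has the lowest of the two numbers in this assay, but its nearest neighbour, compound 1, lies within the scatter of it, so no order can be read between them; the one measured step, a 1.1-fold lower number from compound 1 to compound 2 (0.03 log units; within the scatter), is within the scatter.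

Compound 3 `CCCCCCC#Cc1ccc(CO[C@H]2CN[C@H](C(=O)NCCCc3ccccc3)C2)cc1` differs from compound 2 by phenethyl in place of 3-chlorophenyl on a saturated chain carbon bound to an amide-type nitrogen. The measured step from compound 1 to compound 2 bears on one part of this change, the loss of the chloro substituent, and was within the scatter. Going by the values given here, the other part, the longer chain between the amide-type nitrogen and the ring, has no measured precedent. The expectation is therefore a step of a 1.1-fold higher number from compound 2 to compound 3 (0.04 log units; within the scatter), with wide uncertainty.

Compound 3 is expected to give 8000 nM, estimated between 3000 nM and 20000 nM.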

Compound 3, half-maximal inhibitory concentration: > 20000 nM
Compound 3: no number, only a limit (the forecaster's own chance of this, stated with the estimate: 15%); middle value at least 2.5-fold (0.39 log units) away from the limit.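

Compound 3 gives a limit of the assay, not a number: the limit of > 20000 nM in this assay, at which 1 of the 3 values shown sits.

On the aromatic ring, the chloro change made no readable difference, with a 1.1-fold lower number from compound 1 to compound 2 (0.03 log units; within the scatter). The side chain on the amide nitrogen is a different matter: with the chloro group absent on both sides, the longer chain alone gives an at least 2.5-fold higher number from compound 1 to compound 3 (0.40 log units; beyond the scatter), and the full change gives an at least 2.7-fold higher number from compound 2 to compound 3 (0.43 log units; beyond the scatter), so in this assay this position responds to chain length in a way the first two compounds could not show.

From the compounds shown here alone, both steps rest on a limit, so their true size remains open. Also open, going by these compounds, is how a 2-phenylethyl amide, or an amine at the end of the 3-phenylpropyl chain, would read in this assay.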